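The source may hold more compounds than are shown below. What is called first, only, known or untested is meant among the compounds shown, and "the series" means these compounds.

Series in a functional assay on HepG2 cells (Homo sapiens) for inhibition, read by MTT assay, with a stated time of 48 h; a higher number here means a weaker inhibitor of growth, a lower number a stronger inhibitor of growth:
Compound 1 `Cn1cc(C2CC(c3ccccc3)=NN2C(=O)c2cccnc2)c2ccccc21`: 4630 nM
Compound 2 `Cn1cc(C2CC(c3ccccc3)=NN2C(=O)c2ccc(Cl)nc2)c2ccccc21`: 7910 nM
Compound 3 `Cn1cc(C2CC(c3ccccc3)=NN2C(=O)c2cccnc2Cl)c2ccccc21`: > 10000 nM, a limit of the assay and not a number

Among the compounds with values here, compound 1 holds one of only two true numbers, and no clear gap separates the pair: a 1.7-fold higher number from compound 1 to compound 2 (0.23 log units; within the scatter). The remaining entry sits at the limit of > 10000 nM in this assay, at which 1 of the 3 values shown sits.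

Compound 4 `COc1ccc2c(c1)c(C1CC(c3ccccc3)=NN1C(=O)c1cccnc1)cn2C` keeps the core of compound 1 and carries methoxy in place of hydrogen on an aromatic carbon of a six-membered aromatic ring of carbon only (methoxy in place of hydrogen on an aromatic carbon). Within the data shown here, no measured step touches that ring. The nearest guides are the two cases of chloro in place of hydrogen on an aromatic carbon, both in the group on the carbonyl: a 1.7-fold higher number from compound 1 to compound 2 (0.23 log units; within the scatter) and an at least 2.1-fold higher number from compound 1 to compound 3 (0.33 log units; beyond the scatter). They involve a different group at a different place, so they bear only weakly on this change. No step beyond the scatter is therefore expected in this assay, although a drift toward a higher number remains possible. The expected step is a 1.1-fold higher number from compound 1 to compound 4 (0.03 log units; within the scatter). For compound 4 the estimated value is 5000 nM, with an expected range of 1800 nM to 10000 nM.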

Compound 4, concentration for 50% growth inhibition: 5110 nM
Estimate against measurement, compound 4: 1.0-fold (0.01 log units) below; the range from low to high includes it.
By their numbers in this assay, from the lowest: compounds 1, 4 and 2 (each within the scatter of the next). At a limit, above all of these: compound 3.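

In this assay, within the data shown here, the one measured change on the six-membered aromatic ring of carbon only, methoxy in place of hydrogen, gives a 1.1-fold higher number from compound 1 to compound 4 (0.04 log units; within the scatter). Unlike the earlier steps, which all lie in the group on the carbonyl, this step shows that the shared core accepts an added group at this position without a change beyond the scatter, although this rests on a single pair of compounds. Nothing at hand gives a cause for this step.

Open, going by these compounds, is whether this position also accepts groups of another kind, such as an amine, a carboxylic acid or a longer chain in place of methoxy. Also open, on these data alone, is whether methoxy elsewhere on this ring would give a similar result, or whether it would do so alongside the chloro groups of compound 2 and compound 3.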